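Urea Substituent Swap on a Quinoline Core: Cytotoxicity Outlook

A few compounds are considered here, and "the series" means these few. Any claim that something is new, unique, unknown or untested is made for them only; others in the source may bear on it.

Measured compounds:
compound 1 `COC(=O)c1ccc(NC(=O)Nc2cc(C)nc3ccccc23)cc1` — 17000 nM
compound 2 `Cc1cc(NC(=O)Nc2ccc(N(C)C)cc2)c2ccccc2n1` — > 25000 nM
compound 3 `Cc1cc(NC(=O)Nc2ccc(SC(F)(F)F)cc2)c2ccccc2n1` — 10000 nM

Three ureas sharing one core differ only in the group on the outer aromatic ring. In an ADME assay on Raji cells (Homo sapiens) for cytotoxicity, with a stated time of 72 h (on this read-out lower numbers stand for an effect already at smaller amounts and higher numbers for an effect only at larger amounts of compound), compound 1 gives 17000 nM. For compound 2 the read-out is a limit of the assay, (the limit of > 25000 nM in this assay, at which 1 of the 3 values shown sits), not a number. Compound 3 gives the lowest of the two numbers shown, and the nearest is compound 1, a gap within the scatter, as a 1.7-fold lower number from compound 1 to compound 3 (0.23 log units; within the scatter) shows; the step from the limit is an at least 2.5-fold lower number from compound 2 to compound 3 (0.39 log units; beyond the scatter), which is at least modest.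

Compound 4 `Cc1cc(NC(=O)Nc2ccc(C(C)(C)C)cc2)c2ccccc2n1` is not yet measured. It differs from compound 3 by tert-butyl in place of (trifluoromethyl)sulfanyl on an aromatic carbon. Within the data shown here, no measured step exchanges tert-butyl for anything, so only the two steps that bring in (trifluoromethyl)sulfanyl bear on it, a 1.7-fold lower number from compound 1 to compound 3 (0.23 log units; within the scatter) and an at least 2.5-fold lower number from compound 2 to compound 3 (0.39 log units; beyond the scatter), and they show that changing this group moves the number little to modestly. A step of about a 1.3-fold higher number from compound 3 to compound 4 (0.11 log units; within the scatter) is therefore expected, within the scatter or slightly toward a higher number. Compound 4 is estimated at 13000 nM, between 5000 nM and 25000 nM.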

Compound 4, half-maximal effective concentration: > 25000 nM
Compound 4 was reported as a limit; the forecaster's own chance of this, stated with the estimate: 15%; at least 1.9-fold (0.28 log units) between middle value and limit.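

In this assay, an at least 2.5-fold higher number from compound 3 to compound 4 (0.39 log units; beyond the scatter), so a change at this place can move the read-out beyond the scatter even when the incoming group is not dimethylamino; until now only the step from compound 2 had shown that. The picture is less clear-cut against methoxycarbonyl, with an at least 1.4-fold higher number from compound 1 to compound 4 (0.16 log units; that floor lies within the scatter), which leaves compound 4 not clearly separated from compound 1. Compound 4 now shares a limit of the assay with compound 2, so the step between them cannot be read: the limit of > 25000 nM in this assay, at which 2 of the 4 values shown sit.

As far as these compounds go, how far the true values of compound 2 and compound 4 lie past that limit stays open, and with it any order between tert-butyl and dimethylamino. Also open, from the compounds shown here alone, is whether a carboxylic acid, a primary amine or a longer alkyl chain on this aromatic carbon would give a number or another limit.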